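Acetamido for cyano on a second fluorophenyl core

The source may report more compounds than this note shows. Statements on the series, on what has been measured and on what is new or still open speak of the compounds shown alone.

Measured so far:
compound 1 `N#Cc1ccc(S(=O)(=O)N2C/C(=C\c3ccccc3F)C(=O)/C(=C/c3ccccc3F)C2)cc1` with 14600 nM;
compound 2 `CC(=O)Nc1ccc(S(=O)(=O)N2C/C(=C\c3ccccc3F)C(=O)/C(=C/c3ccccc3F)C2)cc1` with 7500 nM;
compound 3 `N#Cc1ccc(S(=O)(=O)N2C/C(=C\c3cccc(F)c3)C(=O)/C(=C/c3cccc(F)c3)C2)cc1` with 4500 nM.

All three were tested in a functional assay on SMMC-7721 cells (Homo sapiens) for cytotoxicity, read by MTT assay, with a stated time of 24 h; a higher number here means a weaker inhibitor, a lower number a stronger inhibitor. Compound 1 and compound 2 share one core and differ in a single place: acetamido in place of cyano on an aromatic carbon. That change gave a 1.9-fold lower number from compound 1 to compound 2 (0.29 log units; within the scatter). Compound 3 carries a different core, built from the same atoms joined differently; how the two cores differ is not broken down here. Its value sits close to that of compound 2, and its number is lower than that of compound 1.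

Compound 4 `CC(=O)Nc1ccc(S(=O)(=O)N2C/C(=C\c3cccc(F)c3)C(=O)/C(=C/c3cccc(F)c3)C2)cc1` has not yet been measured. It stands to compound 3 as compound 2 stands to compound 1: acetamido in place of cyano on an aromatic carbon. The place of the change is the same in both pairs, so this is the same change made once more. If it acts as it did from compound 1 to compound 2, compound 4 is expected to show a 1.9-fold lower number from compound 3 to compound 4 (0.27 log units; within the scatter) in this assay, a step that rests on the earlier one alone. On that basis compound 4 is estimated at 2400 nM, with a likely range from 1100 nM to 5200 nM.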

Compound 4, half-maximal inhibitory concentration: 10300 nM
For compound 4 the middle estimate is 4.3-fold (0.63 log units) below the measured one; measured number outside the range, above it.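

On the core of compound 3, acetamido in place of cyano gave a 2.3-fold higher number from compound 3 to compound 4 (0.36 log units; beyond the scatter) in this assay, which runs against the earlier step on the core of compound 1, a step that itself stayed within the scatter. Set side by side, the two steps differ by more than repeated measurements would explain: the same change on two cores in this assay, a 1.9-fold lower number (0.29 log units; within the scatter) from compound 1 to compound 2 and a 2.3-fold higher number (0.36 log units; beyond the scatter) from compound 3 to compound 4, 4.5-fold (0.65 log units) apart, beyond the scatter of two such steps. This shows that the effect of this change did not carry over from one core to the other, so a step measured on one core was a poor guide to the same step on the other; it does not show why the two cores part ways, and two pairs cannot say which of them is the exception.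

The compounds shown leave open how other groups at this place on the aromatic ring, such as an amine or a carboxylic acid, would behave on each core. They also leave open whether such groups would split the two cores in the same way or give steps that agree.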